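Amide side-chain replacement in a vitamin D receptor series

A few compounds are considered here, and "the series" means these few. Any claim that something is new, unique, unknown or untested is made for them only; others in the source may bear on it.

Measured so far:
Compound 1, `CCn1c(C(=O)NCCN(C)C)ccc1C(CC)(CC)c1ccc(OCC(=O)C(C)(C)C)c(C)c1`: in an assay on HL-60 cells for agonist activity at vitamin D3 receptor (Homo sapiens), read by microscopy, with a stated time of 96 h (a lower number here means that less compound is needed, a higher number that more compound is needed for the effect), compound 1 gives 77 nM.
Compound 2, `CCn1c(C(=O)NCCN)ccc1C(CC)(CC)c1ccc(OCC(=O)C(C)(C)C)c(C)c1`: in this assay compound 2 gives 120 nM.
Compound 3, `CCn1c(C(=O)NCCN(C)C)ccc1C(CC)(CC)c1ccc(OCC(O)C(C)(C)C)c(C)c1`: in this assay compound 3 gives 14 nM.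

Compound 3 gives the lowest of the three numbers in this assay. Its nearest neighbour is compound 1, separated from it by the step of a 5.5-fold lower number from compound 1 to compound 3 (0.74 log units; beyond the scatter); compound 2 lies further off, as its own value shows. The other measured step, a 1.6-fold higher number from compound 1 to compound 2 (0.19 log units; within the scatter), concerns the amide side chain and stays within the scatter.

Compound 4, `CC[C@@H](C)[C@H](NC(=O)c1ccc(C(CC)(CC)c2ccc(OCC(O)C(C)(C)C)c(C)c2)n1CC)C(=O)O`, differs from compound 3 in one place: 1-carboxy-2-methylbutyl in place of 2-(dimethylamino)ethyl on an amide-type nitrogen. The step bearing on this region is a 1.6-fold higher number from compound 1 to compound 2 (0.19 log units; within the scatter), which shows that trimming the basic end of the chain changes little. The present change goes further, exchanging the whole chain for a larger, branched group with an acid. The step of a 5.5-fold lower number from compound 1 to compound 3 (0.74 log units; beyond the scatter) lies elsewhere in the molecule and says nothing about this position. Without a measured precedent for an acid here, a moderate rise in the number is expected for compound 4, with wide uncertainty: a 2.5-fold higher number from compound 3 to compound 4 (0.40 log units; beyond the scatter). Compound 4 is therefore estimated at 35 nM in this assay, within 8 nM to 150 nM.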

Compound 4, half-maximal effective concentration: 2.3 nM
Compound 4: the middle estimate sits 15-fold (1.18 log units) above what was measured; measured number outside the range, below it.
By their numbers in this assay, from the lowest: compound 4; then compound 3; then compounds 1 and 2 (each within the scatter of the next).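

In this assay, the substituent on the amide-type nitrogen can move the number beyond the scatter: 1-carboxy-2-methylbutyl in place of 2-(dimethylamino)ethyl gives a 6.1-fold lower number from compound 3 to compound 4 (0.78 log units; beyond the scatter). The earlier step in this chain, a 1.6-fold higher number from compound 1 to compound 2 (0.19 log units; within the scatter), exchanged only dimethylamino for amino, whereas this change shows that a low number in this series does not depend on keeping an amine on the chain, since compound 4 carries none and still gives the lowest number of the four compounds. No measurement at hand accounts for the size or direction of this step.

The carboxylic acid, the branched chain and the two defined stereocentres all enter together, so a methyl ester or primary amide in place of the acid, a simple carboxymethyl group and the opposite stereoisomers would be needed to separate their contributions. As far as these compounds go, it also remains open whether 1-carboxy-2-methylbutyl gives a similar step alongside the (tert-butyl)carbonyl group of compound 1, rather than the 1-hydroxy-2,2-dimethylpropyl group of compound 3.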